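Trimming the Urea Nitrogen: Methyl to Hydrogen

The source may report more compounds than this note shows. Statements on the series, on what has been measured and on what is new or still open speak of the compounds shown alone.

Compound 3 `CNC(=O)N1CC1C#N` was tested in a functional assay on MCF7 cells (Homo sapiens) for inhibition (on this read-out higher numbers stand for weaker inhibition and lower numbers for stronger inhibition), and gave 17000 nM. Among the two plain numbers in this series it stands highest. The nearest is compound 1 `N#CC1CN1C(=O)NCc1ccccc1`, which in this assay gives 6000 nM, a gap beyond the usual scatter. Compound 2 `N#CC1CN1C(=O)Nc1ccc(S(N)(=O)=O)cc1` reached only a limit of the assay, > 15000 nM; this is the limit of > 15000 nM in this assay, at which 1 of the 3 values shown sits.

Compound 4 `N#CC1CN1C(N)=O` differs from compound 3 in one place: hydrogen in place of methyl on an amide-type nitrogen. For such a small change the step of a 1.1-fold higher number from compound 3 to compound 4 (0.02 log units; within the scatter) is expected to stay within the scatter, perhaps drifting toward weaker inhibition. Compound 4 is therefore estimated at 18000 nM, with a range from 7000 nM to 45000 nM.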

Compound 4, half-maximal inhibitory concentration: > 54000 nM
Compound 4: a limit, no number (the forecaster's own chance of this, stated with the estimate: 55%); middle value at least 3.0-fold (0.47 log units) from the limit.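

Hydrogen in place of methyl on an amide-type nitrogen weakens inhibition in this assay, with an at least 3.1-fold higher number from compound 3 to compound 4 (0.50 log units; beyond the scatter). Going by these compounds alone, this is the first change that can be read on its own, as no two of compounds 1, 2 and 3 differ in one place, and it shows that a single methyl at this nitrogen counts. Compound 4 gives no plain number, only a limit of the assay: the limit of > 54000 nM in this assay, at which 1 of the 4 values shown sits.

As far as these compounds go, the full size of the step therefore stays open. From the compounds shown here alone, it also remains open whether an ethyl or propyl chain on this nitrogen would lower the number further than methyl does.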